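The source may report more compounds than this note shows. Statements on the series, on what has been measured and on what is new or still open speak of the compounds shown alone.

In a functional assay on RAW264.7 cells (Mus musculus) for inhibition, read by fluorescence, with stated times of 1 h, 24 h and 30 min (on this read-out higher numbers stand for weaker inhibition and lower numbers for stronger inhibition), the first two compounds set the frame. Compound 1, `O=C(/C=C/c1ccc(C(F)(F)F)cc1)c1ccccc1O`, gives a reading that is a limit of the assay rather than a number, > 10000 nM. Compound 2, `O=C(/C=C/c1ccc(C(F)(F)F)cc1)c1cccc(O)c1`, likewise returns only a limit, > 10000 nM. The change between them is 3-hydroxyphenyl in place of 2-hydroxyphenyl on a carbonyl carbon, and the step it makes is a step that the two limits leave unreadable from compound 1 to compound 2; that it cannot be sized rests on (the limit of > 10000 nM in this assay, at which 2 of the 3 values shown sit).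

Compound 3, `O=C(/C=C/c1cccc(OC(F)(F)F)c1)c1ccccc1O`, carries the trifluoromethoxy group on the other ring; in this assay compound 3 stands at "not determined" (no result reported), so no result is reported for it. How the core of compound 3 differs from the core of compound 1 is not broken down here.

Compound 4, `O=C(/C=C/c1cccc(OC(F)(F)F)c1)c1cccc(O)c1`, has yet to be measured. It stands to compound 3 as compound 2 stands to compound 1: the change is 3-hydroxyphenyl in place of 2-hydroxyphenyl on a carbonyl carbon, and the surroundings of the place are the same, so it is the same change. With both measured partners at the limit, the pair of compound 1 and compound 2 gives no direction to carry over. On that footing compound 4 is expected to give 15000 nM, estimated between 5000 nM and 50000 nM, most likely again only as a limit.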

Compound 4, half-maximal inhibitory concentration: > 10000 nM
Compound 4: only a limit was reported; the forecaster's own chance of this, stated with the estimate: 80%; the middle value is on the limit's open side.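

In this assay, among the compounds shown here, compound 3 stands at "not determined" (no result reported), so no step to compound 4 can be read. Compound 4 gives > 10000 nM, which is a limit of the assay and not a number. The compounds shown leave open whether 3-hydroxyphenyl in place of 2-hydroxyphenyl changes inhibition at all, and how strongly any of them inhibits: the limit of > 10000 nM in this assay, at which 3 of the 4 values shown sit.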